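The source may hold more compounds than are shown below. What is called first, only, known or untested is meant among the compounds shown, and "the series" means these compounds.

In an ADME assay on the whole organism with Oryza sativa as the target, tested at 0.1 uM (on this read-out higher numbers stand for a weaker effect at the one concentration tested and lower numbers for a stronger effect), compound 3 `CCCc1ccc(NC(=O)N[C@@H](C)c2ccccc2)cc1` gives 97%, the top of the three numbers seen so far. Compound 1 `CC(C)c1cccc(NC(=O)N[C@@H](C)c2ccccc2)c1` gives 95%, which lies within the scatter of compound 3, while compound 2 `CCCc1ccc(NC(=O)N[C@H](C)c2ccccc2)cc1` gives 33%. Among the compounds with values here, the step of a number 64 percentage points higher from compound 2 to compound 3 (beyond the scatter) is the one large change seen, and it rests on (the fact that compounds 2 and 3 differ only in the configuration as drawn). Compound 4 `CCCCCc1ccc(NC(=O)N[C@@H](C)c2ccccc2)cc1` differs from compound 3 by ethyl in place of hydrogen on a saturated chain carbon, three bonds along the chain from an aromatic carbon. Within the data shown here, no measured step lengthens the chain in this way, so the single stereochemical step gives no guide to it, and no step beyond the scatter is expected from compound 3. Compound 4 is therefore expected to give about 90%, between 65% and 100%. That expectation means a step of a number 7 percentage points lower from compound 3 to compound 4 (within the scatter).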

Compound 4, a percentage reported as activity, at one concentration (the size of the read-out at that concentration, not a potency): 98%
Beside the measured number, compound 4's estimate is 8 percentage points below it, within the range that was stated.
By their numbers in this assay, from the lowest: compound 2; then compounds 1, 3 and 4 (each within the scatter of the next).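

With the configuration held as drawn, propyl to pentyl gives a number 1 percentage points higher from compound 3 to compound 4 (within the scatter), so ethyl in place of hydrogen on this chain carbon leaves the number in the same range. This is the first one-place change shown that alters the chain rather than the configuration, and unlike the configuration step, it stays within the scatter. Nothing measured here explains this outcome.

From the compounds shown here alone, whether pentyl behaves the same way in the opposite configuration, that of compound 2, remains open. So does the effect of a chain ending in an amine or a carboxylic acid.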